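This account rests on a few compounds, and the source may have more. Where it says the series, first, only, none or still open, it means among the compounds named here.

Measured compounds in an assay on isolated protein for inhibition of serine protease 1 (Bos taurus); a higher number here means a weaker inhibitor, a lower number a stronger inhibitor:
compound 1 `CC(=N)N1CCC(Oc2ccc(NCc3ccc4ccc(C(=N)N)cc4c3)cc2[N+](=O)[O-])CC1` gives 7 nM
compound 2 `N=C(N)c1ccc(O)c(/C=C/CNc2ccc(OC3CCN(C(N)=O)CC3)c(C(F)(F)F)c2)c1` gives 520 nM
compound 3 `CCOC(=O)c1cc(NC/C=C/c2cccc(C(=N)N)c2)ccc1OC1CCN(C(C)=N)CC1` gives 40 nM

Compound 2 stands at the highest number of the three, beyond the scatter against compound 3 and further still against compound 1, so it is the weakest inhibitor of the set. Compound 4 `CC(=N)N1CCC(Oc2ccc(NC/C=C/c3cc(C(=N)N)ccc3O)cc2C(F)(F)F)CC1` is not yet measured. It differs from compound 2 in one place: a group of 3 heavy atoms (2 carbon, 1 nitrogen; no ring) in place of a group of 3 heavy atoms (1 carbon, 1 nitrogen, 1 oxygen; no ring), on an amine nitrogen in a ring. Going by the values given here, the group that enters is the one compounds 1 and 3 carry on an amine nitrogen in a ring, and both give lower numbers than compound 2. Among the compounds with values here, no measured pair isolates this change, so the expectation rests on that comparison alone. For compound 4 a step to a lower number is expected, an 8.7-fold lower number from compound 2 to compound 4 (0.94 log units; beyond the scatter), beyond the scatter. The estimate for compound 4 in this assay is 60 nM, in the range 15 nM to 200 nM.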

Compound 4, inhibition constant: 200 nM
Compound 4: the middle estimate sits 3.3-fold (0.52 log units) below what was measured, within the range that was stated.
By their numbers in this assay, from the lowest: compound 1; then compound 3; then compound 4; then compound 2.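

In this assay, the group entering in place of carbamoyl on the amine nitrogen in a ring gives a 2.6-fold lower number from compound 2 to compound 4 (0.41 log units; beyond the scatter) with the rest of the structure unchanged. Going by these compounds alone, this is the first isolated reading of the change: the position responds, but only modestly, so the lower numbers of compounds 1 and 3 cannot be credited to this group alone. Nothing available explains the step.

Still open, going by these compounds, is how an acetyl or a methyl on this nitrogen would read. Also open, on these data alone, is whether the step holds on the core of compound 1 or compound 3.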